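A few compounds are considered here, and "the series" means these few. Any claim that something is new, unique, unknown or untested is made for them only; others in the source may bear on it.

Measured compounds:
compound 1, `COc1nc(-c2ccccc2)cc(-c2ccc(F)cc2)c1C#N`, an assay on isolated protein for inhibition of sulfide:quinone oxidoreductase, mitochondrial (Homo sapiens); on this read-out lower numbers stand for stronger inhibition and higher numbers for weaker inhibition: 25 nM
compound 2, `COc1nc(-c2ccccc2)cc(-c2ccncc2)c1C#N`, this assay: 541 nM

Compound 2 stands highest of the two numbers; its nearest neighbour is compound 1. For the measured compounds named here, the only measured step, a 22-fold higher number from compound 1 to compound 2 (1.34 log units; beyond the scatter), is large and beyond the scatter, and it bears directly on the next step, since compound 3, `COc1nc(-c2ccccc2)cc(-c2ccccc2)c1C#N`, differs from compound 2 by phenyl in place of pyridin-4-yl on an aromatic carbon. This removes the ring nitrogen that the large step introduced, so a large drop back toward the number of compound 1 is expected. Compound 3 is therefore estimated at 35 nM, range 12 nM to 110 nM. The expected step is a 15-fold lower number from compound 2 to compound 3 (1.19 log units; beyond the scatter).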

Compound 3, half-maximal inhibitory concentration: 53 nM
Compound 3: middle estimate off by 1.5-fold (0.18 log units), on the low side, within the range that was stated.
By their numbers in this assay, from the lowest: compound 1; then compound 3; then compound 2.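

In this assay, phenyl in place of pyridin-4-yl gives a 10-fold lower number from compound 2 to compound 3 (1.01 log units; beyond the scatter) and so recovers most of the loss seen with the ring nitrogen. Hydrogen in place of fluoro gives only a 2.1-fold higher number from compound 1 to compound 3 (0.33 log units; beyond the scatter) at the same position, a modest step but beyond the scatter, so the two changes differ clearly in size. Nothing available explains either step.

Still open, as far as these compounds go, is how chloro, methoxy or an amine on this phenyl ring compares with fluoro, and whether pyridin-3-yl matches pyridin-4-yl. The methoxy, cyano and other phenyl groups stay constant, so their contributions cannot be read.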